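A few compounds are considered here, and "the series" means these few. Any claim that something is new, unique, unknown or untested is made for them only; others in the source may bear on it.

Compound 1 `COC(=O)c1cc(-c2cccc(NC(=O)c3ccc(/C=C/C(=O)c4ccccc4)cc3)c2)on1` in an ADME assay on Vero cells (Chlorocebus sabaeus) for cytotoxicity, read by MTT assay, with a stated time of 72 h (on this read-out higher numbers stand for lower toxicity in this test and lower numbers for higher toxicity in this test), gives > 50 ug/mL, which is a limit of the assay and not a number.
Compound 2 `COC(=O)c1cc(-c2cccc(NC(=O)c3ccc(/C=C/C(=O)c4cc(F)ccc4F)cc3)c2)on1` in this assay gives > 40 ug/mL, which is likewise a limit.

Within the data shown here, compound 2 thus stands only at a limit in this assay, at the limit of > 40 ug/mL in this assay, at which 1 of the 2 values shown sits, and the one further value shown is also a limit, at the limit of > 50 ug/mL in this assay, at which 1 of the 2 values shown sits. Among the measured compounds shown here, the single measured step, a step that the two limits leave unreadable from compound 1 to compound 2, is left unreadable by the two limits. Compound 3 `COC(=O)c1cc(-c2cccc(NC(=O)c3ccc(/C=C/C(=O)c4ccc(F)cc4)cc3)c2)on1` differs from compound 2 by 4-fluorophenyl in place of 2,5-difluorophenyl on a carbonyl carbon. For the measured compounds named here, no measured step other than the unreadable one bears on this change, so nothing beyond the scatter can be read from it. In this assay the step that the limit leaves unreadable from compound 2 to compound 3 is therefore expected to be none beyond the scatter. Compound 3 is expected to give about 50 ug/mL, within 30 ug/mL to 100 ug/mL, and most probably the assay will again report only a limit.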

Compound 3, half-maximal cytotoxic concentration: > 20 ug/mL
Compound 3 was reported as a limit; the forecaster's own chance of this, stated with the estimate: 80%; the middle value is on the limit's open side.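

The values of compound 1, compound 2 and compound 3 are all limits, so neither step leading to compound 3 can be read. The compounds shown leave open where any of the three actually lies in this assay, and whether changing the fluoro substitution on the phenyl alters it.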